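A few compounds are considered here, and "the series" means these few. Any claim that something is new, unique, unknown or untested is made for them only; others in the source may bear on it.

Measured so far in an assay on CHO cells for displacement of a labelled ligand from adenosine receptor A3 (Homo sapiens), read by radioligand binding; a higher number here means a weaker inhibitor, a lower number a stronger inhibitor:

Compound 1 `COc1cc(-c2cc3cccc(C)c3oc2=O)cc(OC)c1OC` — 9820 nM
Compound 2 `CC(=O)Oc1ccc(-c2cc3ccc(OC(C)=O)c(OC(C)=O)c3oc2=O)cc1` — 6140 nM
Compound 3 `CC(=O)Oc1ccc(-c2cc3cccc(OC(C)=O)c3oc2=O)cc1OC(C)=O` — 22000 nM

Compound 3 stands at the highest number of the three, so it is the weakest inhibitor of the set in this assay; its nearest neighbour is compound 1 and its furthest is compound 2, both gaps beyond the scatter. Going by the values given here, no pair of measured compounds differs in only one place, so no single step has been measured.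

Compound 4 `CC(=O)Oc1ccc(-c2cc3ccc(OC(C)=O)c(OC(C)=O)c3oc2=O)cc1OC(C)=O` is the next compound to be measured. Relative to compound 3 the change is acetoxy in place of hydrogen on an aromatic carbon, an acetoxy in place of hydrogen on an aromatic carbon. The resulting substitution on the fused ring matches that of compound 2, while the substitution on the attached phenyl matches that of compound 3. Among the compounds with values here, with no measured step to lean on, only a modest move is expected in this assay, most likely toward a lower number. Because compound 2 gives 6140 nM and compound 3 gives 22000 nM, compound 4 is expected at 12000 nM, within 4000 nM to 40000 nM. That estimate implies a step of a 1.8-fold lower number from compound 3 to compound 4 (0.26 log units; within the scatter).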

Compound 4, inhibition constant: 23400 nM
The estimate for compound 4 lay 2.0-fold (0.29 log units) below the measured number; measured number inside the range.
By their numbers in this assay, from the lowest: compounds 2 and 1 (each within the scatter of the next); then compounds 3 and 4 (each within the scatter of the next).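

In this assay, going by these compounds alone, acetoxy in place of hydrogen on an aromatic carbon of the fused system, ortho to an acetoxy group, gives a 1.1-fold higher number from compound 3 to compound 4 (0.03 log units; within the scatter), so this position accepts the added acetoxy with no step that can be told from the scatter. The same exchange at another aromatic carbon gives a 3.8-fold higher number from compound 2 to compound 4 (0.58 log units; beyond the scatter), which lies beyond the scatter, so in these two steps acetoxy in place of hydrogen does not read alike at both carbons. Nothing measured here accounts for either step.

Open, as far as these compounds go, is whether a free hydroxy group or an amine at the position ortho to the acetoxy group would read differently from acetoxy. Also open, from the compounds shown here alone, is whether either step would hold with other substituents on the shared core.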